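The source may report more compounds than this note shows. Statements on the series, on what has been measured and on what is new or still open speak of the compounds shown alone.

Measured compounds in a functional assay on the whole organism for inhibition, with Rattus norvegicus as the target, at a dose of 3 mg/kg by the oral route; on this read-out higher numbers stand for a stronger effect at the one dose given and lower numbers for a weaker effect:

compound 1, `CC(C)c1ccnc(C(=O)Nc2nn[nH]n2)c1`: 34%
compound 2, `Cc1ccnc(C(=O)Nc2nn[nH]n2)c1`: 42%
compound 3, `O=C(Nc1nn[nH]n1)c1ccccn1`: 29%

Compound 3 sits at the low end of the three numbers. Against compound 1 the gap is small, a number 5 percentage points lower from compound 1 to compound 3 (within the scatter), so these two cannot be ordered. Against compound 2 the gap is larger, a number 13 percentage points lower from compound 2 to compound 3 (beyond the scatter), a modest step beyond the scatter. Between compound 1 and compound 2, a number 8 percentage points higher from compound 1 to compound 2 (within the scatter), nothing separates the two.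

The next compound, compound 4, `CCCCc1ccnc(C(=O)Nc2nn[nH]n2)c1`, differs from compound 3 in one place: butyl in place of hydrogen on an aromatic carbon. Among the measured compounds shown here, the steps that bear on it are the two in which a chain enters at the same aromatic carbon of the shared core, methyl giving the modest gain seen from compound 3 to compound 2 and isopropyl giving only the within-scatter difference between compound 3 and compound 1. For the measured compounds named here, a longer chain has no measured precedent, and the two chains that do have one do not agree on whether the gain holds as the chain grows.

For compound 4 a small rise in this assay is therefore expected, not clearly beyond the scatter. The expected step is a number 6 percentage points higher from compound 3 to compound 4 (within the scatter). Compound 4 is estimated at 35%, with a range of 20% to 50%.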

Compound 4, a percentage reported as inhibition, in the whole organism at one dose (the size of the read-out at that dose, not a potency): 33%
Estimate against measurement, compound 4: 2 percentage points above; the range from low to high includes it.
By their numbers in this assay, from the lowest: compounds 3, 4, 1 and 2 (each within the scatter of the next, the first and the last beyond it).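

In this assay, butyl on the aromatic carbon opposite the ring nitrogen cannot be separated from hydrogen (a number 4 percentage points higher from compound 3 to compound 4 (within the scatter)), so adding these four carbons to the shared core gives no readable change at this position. Butyl also cannot be separated from isopropyl (a number 1 percentage points lower from compound 1 to compound 4 (within the scatter)) or from methyl (a number 9 percentage points lower from compound 2 to compound 4 (within the scatter)), which means the three chains form no readable order among themselves. Among the compounds shown here, the only step beyond the scatter at this position remains the one involving methyl (a number 13 percentage points lower from compound 2 to compound 3 (beyond the scatter)), and butyl does not reproduce it against hydrogen, while no measurement available here bears on the reason for this result.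

On these data alone, whether a group of another kind at this aromatic carbon, such as an amine, a carboxylic acid or a methoxy group, would stand beyond the scatter of hydrogen remains open, as does the behaviour of ethyl or a chain longer than butyl. Since this assay reports the effect at one dose, the compounds shown speak only of a stronger or weaker effect at that dose and leave open whether any of these groups would change the effect at any other dose.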